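Methylamide for Cyclopropyl Ketone on a Bicyclic Amine

The compounds below may be only part of what the source reports. "The series", "measured", "known", "first", "only" and "open" are said of these compounds alone.

compound 1 `COC(=O)N1CC2CNCC2C1`: 16000 nM
compound 2 `O=C(C1CC1)[C@H]1C[C@@H]2CNC[C@@H](C2)C1`: 1300 nM

In an assay on CHO cells for agonist activity at Neuronal acetylcholine receptor; alpha3/beta4 (Homo sapiens), read by FLIPR and calcium flux (a lower number here means that less compound is needed, a higher number that more compound is needed for the effect), compound 1 gives 16000 nM, while compound 2 gives 1300 nM, the lower of the two numbers, and its distance from compound 1 lies beyond the usual scatter. Compound 3 `CNC(=O)[C@H]1C[C@@H]2CNC[C@@H](C2)C1` has not yet been measured in this assay. It differs from compound 2 in one place: methylamino in place of cyclopropyl on a carbonyl carbon. Among the compounds with values here, no comparable pair has been measured, so only a modest rise in the number, expected to be a little beyond the scatter, is foreseen as a 2.3-fold higher number from compound 2 to compound 3 (0.36 log units; beyond the scatter). Compound 3 is estimated at 3000 nM, within 800 nM to 12000 nM.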

Compound 3, half-maximal effective concentration: 100000 nM
Compound 3: middle estimate off by 33-fold (1.52 log units), on the low side; measured number above the stated range.
By their numbers in this assay, from the lowest: compound 2; then compound 1; then compound 3.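

Replacing cyclopropyl with methylamino on a carbonyl carbon gives a 77-fold higher number from compound 2 to compound 3 (1.89 log units; beyond the scatter) in this assay. The earlier compounds shown here did not show how much this single place on the shared core can move the number, and here one swap takes compound 3 to the highest number of the three. What lies behind so large a rise is not explained by anything available. On these data alone, it remains open whether losing the ring or bringing in the nitrogen and its hydrogen counts more: an ethyl group or a dimethylamino group on the same carbonyl carbon would help separate the two.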